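The source may report more compounds than this note shows. Statements on the series, on what has been measured and on what is new or still open speak of the compounds shown alone.

Of the compounds shown here, three have so far been measured in a functional assay on L02 cells (Homo sapiens) for inhibition, read by Griess assay, with stated times of 1 h and 24 h; a lower number here means a stronger inhibitor, a higher number a weaker inhibitor. Compound 1 `CCCc1nn(C)c2c(NC(C)C)nc(/C=C/c3nc(C)c(C)nc3C)nc12` gives 342000 nM in this assay. Compound 2 `CCCCNc1nc(/C=C/c2ccccc2)nc2ccsc12` gives only a limit of the measurement, > 1000000 nM. Compound 3 `FC(F)(F)c1ccc(Nc2nc(/C=C/c3ccccc3)nc3ccsc23)cc1` likewise gives only a limit, > 1000000 nM. Compound 2 thus stands at the limit of > 1000000 nM in this assay, at which 2 of the 3 values shown sit, while compound 1 alone gives a number. Compound 4 `COc1cccc(CNc2nc(/C=C/c3ccccc3)nc3ccsc23)c1` is not yet measured; it differs from compound 2 in one place: 3-methoxyphenyl in place of propyl on a saturated chain carbon bound to a nitrogen on an aromatic ring. Among the compounds with values here, no measured pair differs in a single place, so the size of such a change cannot be read from the data. The step from compound 2 to compound 4 is expected to be none beyond the scatter, a number no higher from compound 2 to compound 4 (the limit leaves the size open), in either direction. Compound 4 is estimated at 1000000 nM, within 300000 nM to 3000000 nM.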

Compound 4, half-maximal inhibitory concentration: > 1000000 nM
Compound 4 ended at the assay's limit; the forecaster's own chance of this, stated with the estimate: 60%; the middle value sits exactly at the limit.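

No step can be read from compound 2 to compound 4, since both give only a limit in this assay: the limit of > 1000000 nM in this assay, at which 3 of the 4 values shown sit.

As far as these compounds go, whether 3-methoxyphenyl in place of propyl changes inhibition at all remains open.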